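The compounds below may be only part of what the source reports. "The series", "measured", "known", "first", "only" and "open" are said of these compounds alone.

In an ADME assay on the whole organism (Rattus norvegicus, strain Wistar) for pharmacokinetics, read by LC-MS, at a dose of 10 mg/kg by the oral route (on this read-out higher numbers stand for higher exposure at the dose given and lower numbers for lower exposure), compound 1 `N=C(N)NCCC[C@H](NC(=O)c1ccc(C(c2ccc(Cl)cc2)c2ccc(Cl)cc2)s1)C(=O)O` gives 275 nM. In this assay compound 2 `N=C(N)NCCC[C@H](NC(=O)c1ccc(C(c2ccccc2)c2ccccc2)s1)C(=O)O` gives 202 nM, a number that lies within the scatter of that of compound 1, so no order between the two can be read. Compound 3 `Cc1cc(C(c2ccccc2)c2ccccc2)sc1C(=O)N[C@@H](CCCNC(=N)N)C(=O)O` differs from compound 2 only by methyl in place of hydrogen on an aromatic carbon. Going by the values given here, no measured pair shows what this change does, and nothing in the two numbers at hand points to a shift in this assay beyond the scatter in either direction. Compound 3 is therefore estimated at 230 nM, with a range of 90 nM to 600 nM. This corresponds to an expected 1.1-fold higher number from compound 2 to compound 3 (0.06 log units; within the scatter).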

Compound 3, maximal plasma concentration: 49.5 nM
Estimate against measurement, compound 3: 4.6-fold (0.67 log units) above, and the stated range ends above it.
By their numbers in this assay, from the lowest: compound 3; then compounds 2 and 1 (each within the scatter of the next).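

Methyl in place of hydrogen on this aromatic carbon, two ring bonds from the ring sulfur, brings a 4.1-fold lower number from compound 2 to compound 3 (0.61 log units; beyond the scatter) in this assay and so gives the first step in the series that lies beyond the scatter. A single added carbon at this place is enough to lower exposure at the dose given. Nothing at hand accounts for the drop.

As far as these compounds go, whether any group here lowers the number or only methyl does stays open; fluorine, ethyl or methoxy at this place would separate the two. Also open, from the compounds shown here alone, is whether methyl does the same on the core of compound 1.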